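The source may report more compounds than this note shows. Statements on the series, on what has been measured and on what is new or still open speak of the compounds shown alone.

Measured so far:
Compound 1 `COc1ccc(-c2cn3cc(C4=CCN(C(=O)C(C)(C)C)CC4)ccc3n2)cc1OC` — 66600 nM
Compound 2 `COc1ccc(-c2cn3cc(C4=CCN(C(=O)c5cccc(C(F)(F)F)c5)CC4)ccc3n2)cc1OC` — 68400 nM

In an ADME assay on HEK293 cells (Homo sapiens) for cytotoxicity, read by MTT assay, with a stated time of 48 h (a lower number here means a stronger inhibitor, a higher number a weaker inhibitor), compound 2 gives 68400 nM, and in this assay compound 1 gives 66600 nM; the step of a 1.0-fold higher number from compound 1 to compound 2 (0.01 log units; within the scatter) lies within the scatter, so the two compounds sit together. Compound 3 `COc1ccc(-c2cn3cc(C4=CCN(C(=O)c5cccs5)CC4)ccc3n2)cc1OC` differs from compound 2 by thiophen-2-yl in place of 3-(trifluoromethyl)phenyl on a carbonyl carbon. Among the measured compounds shown here, the only measured step at this carbonyl carbon, a 1.0-fold higher number from compound 1 to compound 2 (0.01 log units; within the scatter), changed nothing beyond the scatter, so no step beyond the scatter is expected here either. Compound 3 is therefore estimated at 65000 nM, with a range from 30000 nM to 140000 nM, an expected step of a 1.1-fold lower number from compound 2 to compound 3 (0.02 log units; within the scatter).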

Compound 3, half-maximal inhibitory concentration: 98100 nM
Compound 3: middle estimate off by 1.5-fold (0.18 log units), on the low side; low and high end bracket the measured number.
By their numbers in this assay, from the lowest: compounds 1, 2 and 3 (each within the scatter of the next).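

In this assay, thiophen-2-yl on the carbonyl carbon leaves compound 3 within the scatter of both earlier compounds (a 1.4-fold higher number from compound 2 to compound 3 (0.16 log units; within the scatter); a 1.5-fold higher number from compound 1 to compound 3 (0.17 log units; within the scatter)). The position now holds a five-membered aromatic ring with one hetero atom as well as tert-butyl and 3-(trifluoromethyl)phenyl, and all three compounds sit together. No measurement at hand explains this result.
As far as these compounds go, whether a group carrying an amine or a carboxylic acid on this carbonyl carbon would stay within the scatter remains open. So does whether changes elsewhere on the shared core would do so.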